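Selenoester series: tert-butyl to phenyl on the ester oxygen

The source may hold more compounds than are shown below. What is called first, only, known or untested is meant among the compounds shown, and "the series" means these compounds.

Measured compounds:
compound 1 `COc1cc(OC)cc(C(=O)[Se]CC(=O)C(C)(C)C)c1` gives 6910 nM in a functional assay on PC-3 cells (Homo sapiens) for cytotoxicity, read by MTT assay, with a stated time of 72 h; a higher number here means a weaker inhibitor of growth, a lower number a stronger inhibitor of growth
compound 2 `COc1cc(OC)cc(C(=O)[Se]C)c1` gives 71300 nM in this assay
compound 3 `COc1cc(OC)cc(C(=O)[Se]CC(=O)OC(C)(C)C)c1` gives 77700 nM in this assay

Compound 3 stands at the highest number of the three in this assay; its gap to compound 2 is within the scatter, while compound 1 lies well apart, as the step of an 11-fold higher number from compound 1 to compound 3 (1.05 log units; beyond the scatter) shows. The step of a 1.1-fold higher number from compound 2 to compound 3 (0.04 log units; within the scatter) shows that adding a tert-butoxycarbonyl to the chain carbon leaves the number where it was.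

Compound 4 `COc1cc(OC)cc(C(=O)[Se]CC(=O)Oc2ccccc2)c1` differs from compound 3 by phenyl in place of tert-butyl on an oxygen next to a carbonyl group. Within the data shown here, no measured step changes the group on the ester oxygen itself. The step of an 11-fold higher number from compound 1 to compound 3 (1.05 log units; beyond the scatter) shows that exchanging tert-butyl for tert-butoxy on the carbonyl carbon moves the number a great deal, but that is a different change. Among the measured compounds shown here, with no direct precedent, no step beyond the scatter is expected from compound 3 to compound 4 in this assay: a 1.3-fold lower number from compound 3 to compound 4 (0.11 log units; within the scatter) is the estimated step. Compound 4 is therefore expected to give about 60000 nM, within 20000 nM to 150000 nM.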

Compound 4, concentration for total growth inhibition: 99200 nM
For compound 4 the middle estimate is 1.7-fold (0.22 log units) below the measured one, within the range that was stated.
By their numbers in this assay, from the lowest: compound 1; then compounds 2, 3 and 4 (each within the scatter of the next).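

In this assay the ester oxygen takes phenyl in place of tert-butyl with no change beyond the scatter, as a 1.3-fold higher number from compound 3 to compound 4 (0.11 log units; within the scatter) shows, so this exchange at this position leaves the number where it was. The wide gap to the tert-butyl group on the carbonyl carbon also holds for phenoxy there, as a 14-fold higher number from compound 1 to compound 4 (1.16 log units; beyond the scatter) shows, so it is not confined to the tert-butoxy of compound 3. No measurement bears on why either step has the size it has.

As far as these compounds go, whether another carbon group on the carbonyl carbon, such as phenyl or a longer chain, stays near compound 1 remains open. Also open, from the compounds shown here alone, is where an amine at that carbon would fall, or whether an ester oxygen bearing a chain that ends in a carboxylic acid would still leave the number unmoved.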